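The compounds below may be only part of what the source reports. "The series", "measured", "known", "first", "only" and "open" are said of these compounds alone.

Compound 2 `Cc1cc(C)cc(-c2cc(C)c(Nc3ccnc(Nc4ccc(C#N)cc4)n3)c(C)c2)c1` carries the shared core with a 3,5-dimethylphenyl group. In an ADME assay on MT4 cells (Homo sapiens) for cytotoxicity, read by MTT assay, with a stated time of 4 days (a higher number here means that more compound is tolerated, a lower number that less compound is tolerated), compound 2 gives 4140 nM. Among the measured compounds shown here, its only neighbour among the measured compounds is compound 1 `Cc1cc(-c2ccc(Cl)cc2)cc(C)c1Nc1ccnc(Nc2ccc(C#N)cc2)n1`, which in this assay gives 4190 nM; the two values lie within the scatter of each other, so compound 2 cannot be placed above or below compound 1 on these numbers. Compound 3 `Cc1cc(-c2ccccc2Cl)cc(C)c1Nc1ccnc(Nc2ccc(C#N)cc2)n1` is not yet measured. It differs from compound 2 in one place: 2-chlorophenyl in place of 3,5-dimethylphenyl on an aromatic carbon. For the measured compounds named here, one measured step bears on this site, a 1.0-fold lower number from compound 1 to compound 2 (0.01 log units; within the scatter), where one aryl group replaced another without any shift beyond the scatter. Nothing measured sets the 2-chlorophenyl group apart from the other aryl groups at this site. The step from compound 2 to compound 3 is therefore expected to stay within the scatter, a 1.0-fold higher number from compound 2 to compound 3 (0.01 log units; within the scatter). For compound 3 the estimate in this assay is 4200 nM, with an expected range from 2000 nM to 9000 nM.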

Compound 3, half-maximal cytotoxic concentration: 3990 nM
Beside the measured number, compound 3's estimate is 1.1-fold (0.02 log units) above it; low and high end bracket the measured number.
By their numbers in this assay, from the lowest: compounds 3, 2 and 1 (each within the scatter of the next).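

In this assay, replacing 3,5-dimethylphenyl with 2-chlorophenyl gives a step within the scatter (a 1.0-fold lower number from compound 2 to compound 3 (0.02 log units; within the scatter)), so this site now holds a third aryl group with no separation in the number. The new comparison between the two chlorophenyl groups also stays within the scatter (a 1.1-fold lower number from compound 1 to compound 3 (0.02 log units; within the scatter)), so changing 4-chlorophenyl to 2-chlorophenyl does not separate the compounds, which the earlier pair could not show. No measurement available here accounts for this flat result.

Going by these compounds, all three compounds carry a six-membered aromatic ring of carbon only at this site, so it remains open whether an aminophenyl or carboxyphenyl group, or a longer alkyl chain, would move the number beyond the scatter. On these data alone, how changes elsewhere on the shared core would read in this assay also remains open.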